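The compounds below may be only part of what the source reports. "The series", "measured", "known", "first", "only" and "open" are said of these compounds alone.

Two anilides built on the same core have been measured in a functional assay on P388 cells (Mus musculus) for inhibition, read by MTT assay, with a stated time of 72 h; a higher number here means a weaker inhibitor, a lower number a stronger inhibitor. Compound 1 `O=C(Nc1ccccc1Cl)c1ccc(/N=N\c2c[nH]c3ccccc23)cc1` is recorded there as "not active" (no number reported), with no number attached. Compound 2 `Cc1ccc(NC(=O)c2ccc(/N=N\c3c[nH]c4ccccc34)cc2)c(C)c1` is the only compound with a figure: in this assay compound 2 gives 190000 nM, a very weak value, and it stands alone among the numbers shown, so nothing else can be ranked against it.

Compound 3 `Cc1ccccc1NC(=O)c1ccc(/N=N\c2c[nH]c3ccccc23)cc1` has not been measured. It differs from compound 2 by hydrogen in place of methyl on an aromatic carbon, which, read one bond further out, turns a 2,4-dimethylphenyl into a 2-methylphenyl on the amide nitrogen. Among the measured compounds shown here, no pair of measured compounds shows a step of this kind, so the size of the step cannot be taken from data. Given that compound 2 gives 190000 nM, the loss of a single methyl is expected to move this assay by no more than the scatter, if at all, and the expected step from compound 2 to compound 3 is a 1.3-fold higher number from compound 2 to compound 3 (0.12 log units; within the scatter). Compound 3 is therefore estimated at 250000 nM, within a range of 100000 nM to 700000 nM, with a real chance that only an inactive result is reported.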

Compound 3, half-maximal inhibitory concentration: "not active" (no number reported)
Compound 3: no number reported; there is nothing to compare the estimate with.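

Among the compounds shown here, compound 3, like compound 1, is reported without a number, so no step from compound 2 can be read. No evidence at hand bears on this result. The compounds shown leave open how far any change on the aromatic ring of the anilide moves the reading, as compound 2 alone carries a number.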